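From 4-methylpiperidin-1-yl to diethylamino: little change expected

The source may report more compounds than this note shows. Statements on the series, on what has been measured and on what is new or still open speak of the compounds shown alone.

Measured so far in a functional assay on NCI-H460 cells (Homo sapiens) for cytotoxicity, read by MTT assay, with a stated time of 72 h; a lower number here means a stronger inhibitor, a higher number a weaker inhibitor:
- compound 1 `CC1CCN(Cc2ccc3nc(NC(=O)N/N=C/c4cn(Cc5cccc(Cl)c5)c5ccccc45)sc3c2)CC1` gives 280 nM
- compound 2 `CC1CCN(Cc2ccc3nc(NC(=O)N/N=C/c4c[nH]c5ccccc45)sc3c2)CC1` gives 4130 nM
- compound 3 `CN(C)Cc1ccc2nc(NC(=O)N/N=C/c3cn(Cc4ccccc4)c4ccccc34)sc2c1` gives 400 nM

Compound 2 (4130 nM) has the highest number of the three, which makes it the weakest inhibitor in this small set. The next compound to test, compound 4 `CCN(CC)Cc1ccc2nc(NC(=O)N/N=C/c3c[nH]c4ccccc34)sc2c1`, differs from it in one place: diethylamino in place of 4-methylpiperidin-1-yl on a saturated chain carbon bound to an aromatic carbon.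

Among the measured compounds shown here, the only measured step between two compounds differing in one place (a 15-fold higher number from compound 1 to compound 2 (1.17 log units; beyond the scatter)) is large, but it put hydrogen in place of 3-chlorobenzyl on an aromatic nitrogen. That is a different change at a different place, so it says little here. For the measured compounds named here, no measured step isolates the amine. The nearest hint is indirect: compound 1 (280 nM) and compound 3 (400 nM) lie within the scatter of each other, although compound 3 has dimethylamino instead of 4-methylpiperidin-1-yl and also benzyl instead of 3-chlorobenzyl.

On that thin evidence, no shift beyond the scatter is expected in this assay, and the estimated step is small (a 1.0-fold lower number from compound 2 to compound 4 (0.01 log units; within the scatter)). Compound 4 is expected at about (4000 nM), with an estimated range (1800 nM to 9000 nM).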

Compound 4, half-maximal inhibitory concentration: 3140 nM
Compound 4: the middle estimate sits 1.3-fold (0.11 log units) above what was measured; low and high end bracket the measured number.
By their numbers in this assay, from the lowest: compounds 1 and 3 (each within the scatter of the next); then compounds 4 and 2 (each within the scatter of the next).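

In this assay, among the compounds shown here, the step of a 1.3-fold lower number from compound 2 to compound 4 (0.12 log units; within the scatter) is the first measured one that isolates the amine on a saturated chain carbon bound to an aromatic carbon, and it lies within the scatter. With hydrogen on the aromatic nitrogen, a six-membered non-aromatic ring of 7 heavy atoms can thus give way to an open diethylamino group of 5 heavy atoms, and the two compounds cannot be told apart in this test. That step looks small beside a 15-fold higher number from compound 1 to compound 2 (1.17 log units; beyond the scatter) at the aromatic nitrogen, but no measured evidence explains why these two amines read alike.

As far as these compounds go, the amine pair carries only hydrogen on the aromatic nitrogen, so it remains open whether the two amines would also read alike with 3-chlorobenzyl at that place. The compounds shown also leave open whether an amine with a second hetero atom in its ring, such as morpholin-4-yl or 4-methylpiperazin-1-yl, or a carboxylic acid in place of the amine, would fall within the scatter too.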